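The source may report more compounds than this note shows. Statements on the series, on what has been measured and on what is new or still open speak of the compounds shown alone.

Measured in a functional assay on HCT-116 cells (Homo sapiens) for cytotoxicity, read by MTT assay, with a stated time of 72 h; on this read-out lower numbers stand for stronger inhibition and higher numbers for weaker inhibition:
- compound 1 `N[C@H]1CC[C@H](Nc2c(C(=O)NCc3ccc(F)cc3)nc(N3CCCCS3(=O)=O)c3cccnc23)CC1`: > 10000 nM
- compound 2 `CS(=O)(=O)Oc1c(C(=O)NCc2ccc(F)cc2)nc(Br)c2cccnc12`: > 20000 nM
- compound 3 `O=C(NCc1ccc(F)cc1)c1nc(NCCO)c2cccnc2c1O`: "not determined" (no result reported)

None of the three compounds has an exact value in this assay. Compound 2 gives > 20000 nM, which is a limit and not a number. Compound 1 also gives only a limit, > 10000 nM. For compound 3 the entry is "not determined" (no result reported), so it adds nothing to the comparison.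

The next compound to be tested is compound 4 `Nc1cccc(Nc2c(C(=O)NCc3ccc(F)cc3)nc(Br)c3cccnc23)c1`. It carries (3-aminophenyl)amino in place of (methylsulfonyl)oxy on an aromatic carbon, and the bromo group para to that carbon stays: (3-aminophenyl)amino in place of (methylsulfonyl)oxy on an aromatic carbon.

Going by the values given here, no measured pair in this set shows the size of such a change, so any expectation is weakly supported. The reading for compound 2, > 20000 nM, is a limit, so a step can only be judged against that limit. A moderate move toward stronger inhibition is expected, and another result reported only as a limit would be no surprise. The expected change is an at least 2.0-fold lower number from compound 2 to compound 4 (0.30 log units; that floor lies within the scatter). The estimated value for compound 4 is 10000 nM, with an expected range of 2500 nM to 40000 nM.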

Compound 4, half-maximal inhibitory concentration: > 10000 nM
Compound 4: no number, only a limit; the forecaster's own chance of this, stated with the estimate: 45%; the middle value lies on the limit itself.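

In this assay compound 4 gives > 10000 nM, which is a limit and not a number. Compound 2 also gives only a limit, > 20000 nM, so no step can be read between compound 2 and compound 4. The compounds shown leave open how strongly any of them acts, since none has an exact value in this assay.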